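Chloro on the benzyl ring of the lactam series

The source may hold more compounds than are shown below. What is called first, only, known or untested is meant among the compounds shown, and "the series" means these compounds.

Two members of the series carry measurements in an assay on cell membranes from Cerebral cortex for displacement of a labelled ligand from Sigma non-opioid intracellular receptor 1 (Cavia porcellus), read by scintillation counting, with a stated time of 120 min; on this read-out higher numbers stand for weaker inhibition and lower numbers for stronger inhibition. Compound 1 `CN(CCCCN1CCCCC1=O)Cc1ccccc1` is reported only as a limit of the assay, > 3000 nM, and so its place on the scale is not fixed by a number. Compound 2 `CN(CCCCN1C(=O)CCCc2ccccc21)Cc1ccccc1` gives 9 nM in this assay. Going by the values given here, no single-point step between measured compounds is available; the two values show only that compound 2 lies well inside the measurable range while compound 1 sits at the limit, as noted in the limit of > 3000 nM in this assay, at which 1 of the 2 values shown sits.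

Compound 3 `CN(CCCCN1CCCCC1=O)Cc1ccc(Cl)cc1` is the unmeasured compound of interest. It differs from compound 1 by chloro in place of hydrogen on an aromatic carbon. Among the compounds with values here, the measured compounds give no step of this kind to calibrate against, so the size of the change from compound 1 to compound 3 in this assay is not known; the expectation is for no movement beyond the usual scatter, with compound 3 remaining weak.

Compound 3 is therefore estimated at 3000 nM in this assay, within 800 nM to 10000 nM, the expected step being a number no higher from compound 1 to compound 3 (the limit leaves the size open).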

Compound 3, inhibition constant: 770 nM
Compound 3: the middle estimate sits 3.9-fold (0.59 log units) above what was measured, and the stated range ends above it.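

In this assay, going by these compounds alone, the change from phenyl to 4-chlorophenyl gives an at least 3.8-fold lower number from compound 1 to compound 3 (0.59 log units; beyond the scatter), the only step that can be read so far, and it lies beyond the scatter. Compound 1 is reported only as a limit, > 3000 nM. Compound 3 has a number on the scale, so the aromatic carbon para to a large group responds to substitution in this series, but the step is read only as a minimum because one end of it rests on a limit: the limit of > 3000 nM in this assay, at which 1 of the 3 values shown sits.

On these data alone, what remains open is whether this response belongs to chloro itself or would also appear with fluoro, methoxy or an amine at the same place, and how large the step truly is. Also open, as far as these compounds go, is whether the same change from phenyl to 4-chlorophenyl would move the number on the core of compound 2, or whether a longer chain in place of the butyl linker would alter the size of the step on the core of compound 1.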